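A few compounds are considered here, and "the series" means these few. Any claim that something is new, unique, unknown or untested is made for them only; others in the source may bear on it.

Compound 2 `Cc1ccc(Cn2cc(CSC(=S)N3CCN(C(=O)OCc4ccccc4)CC3)nn2)cc1` carries a benzyl carbamate on the shared core and, in a functional assay on MCF7 cells (Homo sapiens) for inhibition, read by MTT assay, with a stated time of 72 h (a lower number here means a stronger inhibitor, a higher number a weaker inhibitor), compound 2 gives 37800 nM. Against the only other measured compound, compound 1 `Cc1ccc(Cn2cc(CSC(=S)N3CCN(C(=O)OC(C)(C)C)CC3)nn2)cc1`, which in this assay gives 19700 nM, compound 2 has the higher of the two numbers, though the step of a 1.9-fold higher number from compound 1 to compound 2 (0.28 log units; within the scatter) lies within the scatter, so the two cannot be ordered.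

Compound 3 `COc1cc(Cn2cc(CSC(=S)N3CCN(C(=O)OCc4ccccc4)CC3)nn2)cc(OC)c1OC` differs from compound 2 at a different place: 3,4,5-trimethoxyphenyl in place of 4-methylphenyl on a saturated chain carbon bound to an aromatic nitrogen. Within the data shown here, the one measured step concerns the carbamate ester and does not touch the group on the saturated chain carbon bound to the aromatic nitrogen, so no measured step bears on this change; the data give no guide to its direction or size.

In the absence of such a guide, the number for compound 3 in this assay is expected to stay close to that of compound 2, with the step of a 1.4-fold lower number from compound 2 to compound 3 (0.13 log units; within the scatter) estimated as no change beyond the scatter. Compound 3 is thus estimated at 28000 nM, within a range from 8000 nM to 90000 nM that reflects the lack of any comparable step.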

Compound 3, half-maximal inhibitory concentration: > 128000 nM
Compound 3 ended at the assay's limit; the forecaster's own chance of this, stated with the estimate: 12%; middle value at least 4.5-fold (0.66 log units) away from the limit.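

The group on the saturated chain carbon bound to an aromatic nitrogen, which the earlier pair left untouched, turns out to matter in this assay: 3,4,5-trimethoxyphenyl in place of 4-methylphenyl gives an at least 3.3-fold higher number from compound 2 to compound 3 (0.52 log units; beyond the scatter). The earlier step at the carbamate ester stayed within the scatter, so this is the first change among the compounds shown that moves the number beyond it, and it moves towards a weaker inhibitor. Compound 3 is recorded only at a limit of the assay and not as a number, so the step fixes a smallest size and leaves the full size unknown: the limit of > 128000 nM in this assay, at which 1 of the 3 values shown sits.

From the compounds shown here alone, with only these two groups compared at this place, it remains open whether the loss goes with the three methoxy groups together or with any one of them, and a plain phenyl or an aminophenyl on the same carbon would help to tell these apart. Among these compounds, it is also open whether the same change would have a like effect on the tert-butyl carbamate of compound 1, since the one step at this place was read with the benzyl carbamate alone.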